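Changing the Ring on the Amide Nitrogen

The compounds below may be only part of what the source reports. "The series", "measured", "known", "first", "only" and "open" are said of these compounds alone.

Within the data shown here, compound 1 `COc1ccc2c(=O)c(/C=C/C(=O)Nc3cccc(Cl)c3)coc2c1` is the only member of this small set with a definite number: in a functional assay on HeLa cells (Homo sapiens) for inhibition, read by MTT assay, with a stated time of 48 h (a lower number here means a stronger inhibitor, a higher number a weaker inhibitor), compound 1 gives 11900 nM. Compound 2 `COc1ccc2c(=O)c(/C=C/C(=O)Nc3ccccc3)coc2c1` carries hydrogen in place of chloro on an aromatic carbon; in this assay compound 2 reaches only > 100000 nM, which is a limit of the measurement rather than a number. Compound 3 `COc1ccc2c(=O)c(/C=C/C(=O)Nc3ccc(Cl)cc3)coc2c1` carries 4-chlorophenyl in place of 3-chlorophenyl on an amide-type nitrogen, and in this assay compound 3 likewise stops at a limit, > 100000 nM. Both measured steps therefore weaken inhibition, each resting on (the limit of > 100000 nM in this assay, at which 2 of the 3 values shown sit).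

Compound 4 `CCOc1ccc(NC(=O)/C=C/c2coc3cc(OC)ccc3c2=O)cc1` is not yet measured. It differs from compound 1 by 4-ethoxyphenyl in place of 3-chlorophenyl on an amide-type nitrogen. Both measured steps bear on this change: the chloro is lost, as in compound 2, and the group on the ring is shifted as it is in compound 3. Among the measured compounds shown here, because compound 2 showed an at least 8.4-fold higher number from compound 1 to compound 2 (0.92 log units; beyond the scatter) and compound 3 showed an at least 8.4-fold higher number from compound 1 to compound 3 (0.92 log units; beyond the scatter), a weakening of comparable size is expected for compound 4, although the ethoxy group itself has no measured precedent here. The estimate for compound 4 in this assay is 60000 nM, within 15000 nM to 200000 nM, meaning an expected 5.0-fold higher number from compound 1 to compound 4 (0.70 log units; beyond the scatter).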

Compound 4, half-maximal inhibitory concentration: > 100000 nM
Compound 4: a limit, no number; the forecaster's own chance of this, stated with the estimate: 55%; middle value at least 1.6-fold (0.22 log units) away from the limit.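

Compound 4 also stops at a limit in this assay, not at a number. Replacing 3-chlorophenyl with 4-ethoxyphenyl on the amide-type nitrogen gives an at least 8.4-fold higher number from compound 1 to compound 4 (0.92 log units; beyond the scatter), so a ring carrying an oxygen-linked chain joins the unsubstituted phenyl ring and the 4-chlorophenyl ring in falling short of compound 1, and among the compounds shown only the 3-chlorophenyl amide gives a definite number. The steps from compound 2 to compound 4 and from compound 3 to compound 4 cannot be read, because both ends of each step sit at a limit: the limit of > 100000 nM in this assay, at which 3 of the 4 values shown sit.

The step to compound 4 changes both the group and where it sits on the ring, so the compounds shown cannot separate the effect of swapping chloro for ethoxy from the effect of the new location. Going by these compounds, it also remains open whether a different group in place of the chloro of compound 1, such as a methyl, an amine or a carboxylic acid, would keep a definite number in this assay or would also end at the limit.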